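A few compounds are considered here, and "the series" means these few. Any claim that something is new, unique, unknown or untested is made for them only; others in the source may bear on it.

Measured in an ADME assay on HEK293 cells (Homo sapiens) for cytotoxicity, read by resazurin assay, with a stated time of 48 h; on this read-out lower numbers stand for higher toxicity in this test and higher numbers for lower toxicity in this test:
compound 1 `Cc1ccc(S(=O)(=O)Nc2ccc(-c3nc4ccccc4o3)cc2)cc1` gives 88000 nM;
compound 3 `O=S(=O)(Nc1ccc2oc(-c3ccccc3)nc2c1)c1ccccc1Cl` gives 73000 nM.
For compound 2 `O=S(=O)(Nc1ccc2oc(-c3ccccc3)nc2c1)c1ccc(F)c(C(F)(F)F)c1` this assay reports only a limit, > 100000 nM.

In this assay compound 1 and compound 3 give numbers that lie within the usual scatter of each other, so neither can be set apart from the other. The third value, that of compound 2, is a limit (the limit of > 100000 nM in this assay, at which 1 of the 3 values shown sits), not a number.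

Compound 4 `COc1ccccc1S(=O)(=O)Nc1ccc(-c2nc3ccccc3o2)cc1` has not been measured. It differs from compound 1 by 2-methoxyphenyl in place of 4-methylphenyl on a sulfonyl sulfur. For the measured compounds named here, no step between measured compounds is known, so compound 4 is expected to move little, a 1.1-fold lower number from compound 1 to compound 4 (0.04 log units; within the scatter), with no change beyond the scatter. Compound 4 is estimated at 80000 nM, within 40000 nM to 160000 nM.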

Compound 4, half-maximal cytotoxic concentration: > 100000 nM
Compound 4: only a limit was reported; the forecaster's own chance of this, stated with the estimate: 35%; middle value at least 1.2-fold (0.09 log units) away from the limit.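

In this assay the place on the sulfonyl sulfur now has its first step: 2-methoxyphenyl in place of 4-methylphenyl gives an at least 1.1-fold higher number from compound 1 to compound 4 (0.05 log units; that floor lies within the scatter) and so does not set the two compounds apart. Compound 4 gives > 100000 nM as a limit, not a number. The full size of this step cannot be read because the values stop at a limit: the limit of > 100000 nM in this assay, at which 2 of the 4 values shown sit.

Still open, from the compounds shown here alone, is how an amine or a carboxylic acid in place of 4-methylphenyl on a sulfonyl sulfur would read in this assay and whether either would move the number beyond the scatter.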